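The source may report more compounds than this note shows. Statements on the series, on what has been measured and on what is new or still open speak of the compounds shown alone.

In a functional assay on U-87MG ATCC cells (Homo sapiens) for antiproliferative activity, with a stated time of 3 days (on this read-out lower numbers stand for an effect already at smaller amounts and higher numbers for an effect only at larger amounts of compound), compound 3 `CC(C)(C)OC(=O)N(Cc1ccc(C(F)(F)F)cc1)Cc1ccc(O)c2ncccc12` gives 2 uM, level with compound 1 `Oc1ccc(CN(Cc2cccc(C(F)(F)F)c2)Cc2ccc(O)c3ncccc23)c2cccnc12` at 2 uM. Compound 2 `Oc1ccc(CNCc2ccc(C(F)(F)F)cc2)c2cccnc12` gives > 10 uM, which is a limit of the assay and not a number. Within the data shown here, the only measured step between close neighbours is an at least 5.0-fold lower number from compound 2 to compound 3 (0.69 log units; beyond the scatter), and it comes from tert-butoxycarbonyl in place of hydrogen on an amine nitrogen. Compound 4 `CC(C)(C)OC(=O)N(Cc1cccc(C(F)(F)F)c1)Cc1ccc(O)c2ncccc12` differs from compound 3 by 3-(trifluoromethyl)phenyl in place of 4-(trifluoromethyl)phenyl on a saturated chain carbon bound to an amide-type nitrogen. The measured step lies at another place, so it gives no size for this change. The entering group does already stand in compound 1, which gives 2 uM, although that compound differs elsewhere as well. What is therefore expected in this assay is no change at the digits printed from compound 3 to compound 4 (within the scatter), with no shift beyond the scatter. The estimated value for compound 4 is 2 uM, with an expected range from 0.8 uM to 5 uM.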

Compound 4, concentration for half-maximal effect: > 10 uM
Compound 4: only a limit was reported; the forecaster's own chance of this, stated with the estimate: 10%; middle value at least 5.0-fold (0.69 log units) away from the limit.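

With tert-butoxycarbonyl kept on the nitrogen in this assay, 3-(trifluoromethyl)phenyl in place of 4-(trifluoromethyl)phenyl gives an at least 5.0-fold higher number from compound 3 to compound 4 (0.69 log units; beyond the scatter), so a change that keeps the same atoms and only joins them differently is enough to shift this read-out beyond the scatter. The 3-(trifluoromethyl)phenyl group therefore does not by itself fix the level, for tert-butoxycarbonyl in place of (8-hydroxyquinolin-5-yl)methyl on an amine nitrogen gives an at least 5.0-fold higher number from compound 1 to compound 4 (0.69 log units; beyond the scatter). Both steps have no upper end, because compound 4 stands at a limit of the assay: the limit of > 10 uM in this assay, at which 2 of the 4 values shown sit.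

The compounds shown leave open whether the gain from tert-butoxycarbonyl also holds with 3-(trifluoromethyl)phenyl on the nitrogen. They also leave open how a nitrile or a carboxylic acid in place of trifluoromethyl on this ring would read, or a longer chain on the nitrogen.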